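Dichlorophenyl hydrazone variant of a quinazoline urea series

This account rests on a few compounds, and the source may have more. Where it says the series, first, only, none or still open, it means among the compounds named here.

Measured compounds:
Compound 1, `O=C(N/N=C/c1cccc(Br)c1)Nc1cc2c(Nc3ccc(F)c(Cl)c3)ncnc2cc1O[C@H]1CCOC1`: 32300 nM
Compound 2, `N#Cc1ccc(/C=N/NC(=O)Nc2cc3c(Nc4ccc(F)c(Cl)c4)ncnc3cc2O[C@H]2CCOC2)cc1`: 26400 nM

Both compounds were tested in a functional assay on HepG2 cells (Homo sapiens) for cytotoxicity, read by MTT assay, with a stated time of 72 h; on this read-out lower numbers stand for stronger inhibition and higher numbers for weaker inhibition. Compound 2 gives 26400 nM, and compound 1 gives 32300 nM. For the measured compounds named here, the two numbers lie within the usual scatter of each other, so compound 2 stands level with compound 1, its only neighbour, the sole measured step being a 1.2-fold lower number from compound 1 to compound 2 (0.09 log units; within the scatter).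

Compound 3, `O=C(N/N=C/c1cccc(Cl)c1Cl)Nc1cc2c(Nc3ccc(F)c(Cl)c3)ncnc2cc1O[C@H]1CCOC1`, has not yet been tested. It differs from compound 2 at one place: 2,3-dichlorophenyl in place of 4-cyanophenyl on a carbon with a double bond to nitrogen. Going by the values given here, the one measured step that bears on this change is the exchange of one substituted phenyl for another at the same place, a 1.2-fold lower number from compound 1 to compound 2 (0.09 log units; within the scatter), and it stayed within the scatter. On that basis no step beyond the scatter is expected in this assay for compound 3 either, in either direction; compound 1, which also carries a halogenated phenyl there, gives 32300 nM.

Compound 3 is therefore expected to give about 30000 nM in this assay, within a range of 12000 nM to 75000 nM, which would mean an estimated step of a 1.1-fold higher number from compound 2 to compound 3 (0.06 log units; within the scatter).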

Compound 3, half-maximal inhibitory concentration: 16900 nM
For compound 3 the middle estimate is 1.8-fold (0.25 log units) above the measured one, within the range that was stated.
By their numbers in this assay, from the lowest: compounds 3, 2 and 1 (each within the scatter of the next).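

In this assay, a third substituted phenyl on the carbon with a double bond to nitrogen gives a 1.6-fold lower number from compound 2 to compound 3 (0.19 log units; within the scatter) and, set against the bromine-bearing ring, a 1.9-fold lower number from compound 1 to compound 3 (0.28 log units; within the scatter). Both steps stay within the scatter, so compounds 1, 2 and 3 stand level with one another, whether the ring carries a nitrile, a single bromine or two chlorines, and this level now holds across three different substitution patterns rather than the two seen before. Nothing at hand explains why these exchanges leave the number within the scatter.

On these data alone, all three compounds carry a substituted phenyl at this place, so it remains open how the number would respond to an aliphatic amine, a carboxylic acid or a longer alkyl chain there instead. As far as these compounds go, it is also open whether any exchange at this place can move the number beyond the scatter in this assay, and whether the level seen for these three compounds would hold in another cell line.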